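Swapping the indazole for a benzothiazole on the shared core

The source may report more compounds than this note shows. Statements on the series, on what has been measured and on what is new or still open speak of the compounds shown alone.

Of the compounds shown here, three built on one shared core have been measured in an assay on cells for activation of Cystic fibrosis transmembrane conductance regulator (Homo sapiens), read by fluorescence, with stated times of 10 min and 12 s; a lower number here means that less compound is needed, a higher number that more compound is needed for the effect. Compound 1 `CCN(CC)c1nc(Nc2cccc(C(=O)O)c2)nc(OC(C(F)(F)F)C(F)(F)F)n1` gives 160 nM. Compound 2 `CCN(CC)c1nc(Nc2ccc(F)cc2)nc(OC(C(F)(F)F)C(F)(F)F)n1` gives 700 nM, and compound 3 `CCN(CC)c1nc(Nc2ccc3[nH]ncc3c2)nc(OC(C(F)(F)F)C(F)(F)F)n1` gives 2800 nM. Compound 3 thus stands with the highest number of the three. The nearest step up to it is a 4.0-fold higher number from compound 2 to compound 3 (0.60 log units; beyond the scatter), the furthest an 18-fold higher number from compound 1 to compound 3 (1.24 log units; beyond the scatter). The step to compound 4 `CCN(CC)c1nc(Nc2ccc3ncsc3c2)nc(OC(C(F)(F)F)C(F)(F)F)n1` is 1,3-benzothiazol-6-yl in place of 1H-indazol-5-yl on a nitrogen on an aromatic ring: both groups carry one five-membered aromatic ring with 2 hetero atoms and one six-membered aromatic ring of carbon only, but a hydrogen-bond donor is lost and a hydrogen-bond acceptor gained. Going by the values given here, no measured step exchanges one such pair of groups; the steps that bear on it show only that the group on this nitrogen matters, as in a 4.4-fold higher number from compound 1 to compound 2 (0.64 log units; beyond the scatter) and a 4.0-fold higher number from compound 2 to compound 3 (0.60 log units; beyond the scatter). With nothing pointing one way, a step within the scatter, a 1.4-fold lower number from compound 3 to compound 4 (0.15 log units; within the scatter), is expected for compound 4. Compound 4 is therefore estimated at 2000 nM, in the range 600 nM to 7000 nM.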

Compound 4, half-maximal effective concentration: 50 nM
Beside the measured number, compound 4's estimate is 40-fold (1.60 log units) above it; the measured number lies below the stated range.
By their numbers in this assay, from the lowest: compound 4; then compound 1; then compound 2; then compound 3.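

On the nitrogen of the shared core, two groups with the same ring types and the same number of heavy atoms proved far from interchangeable in this assay: 1,3-benzothiazol-6-yl in place of 1H-indazol-5-yl gives a 56-fold lower number from compound 3 to compound 4 (1.75 log units; beyond the scatter). The 3-carboxyphenyl group also no longer gives the lowest number at this position, with a 3.2-fold lower number from compound 1 to compound 4 (0.51 log units; beyond the scatter), while replacing 4-fluorophenyl gives a 14-fold lower number from compound 2 to compound 4 (1.15 log units; beyond the scatter). No evidence is available that accounts for the size of these steps.

The change from compound 3 to compound 4 loses a hydrogen-bond donor, gains an acceptor and brings in sulfur all at once, so the compounds shown cannot separate these differences. On these data alone, it remains open whether a 1,3-benzoxazol-6-yl group, with oxygen in place of the sulfur, would keep the low number of compound 4.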